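This account rests on a few compounds, and the source may have more. Where it says the series, first, only, none or still open, it means among the compounds named here.

Working notes on the series. Compound 1 `COc1ccc([C@@H]2[C@H](Oc3ccccc3)C(=O)N2c2cc(OC)c(OC)c(OC)c2)cc1OC` gives 26000 nM in a functional assay on MCF7 cells (Homo sapiens) for antiproliferative activity, read by MTT assay, with stated times of 24 h and 72 h; on this read-out lower numbers stand for stronger inhibition and higher numbers for weaker inhibition. Compound 2 `COc1cc(N2C(=O)[C@@H](Oc3ccccc3)[C@H]2c2ccc(C#N)cc2)cc(OC)c1OC` gives 31600 nM in this assay, and compound 3 `COc1cc(N2C(=O)[C@@H](Oc3ccccc3)[C@H]2c2cccc([N+](=O)[O-])c2)cc(OC)c1OC` gives 30000 nM. The three numbers sit within the scatter of one another: a 1.2-fold higher number from compound 1 to compound 2 (0.08 log units; within the scatter), a 1.2-fold higher number from compound 1 to compound 3 (0.06 log units; within the scatter) and a 1.1-fold lower number from compound 2 to compound 3 (0.02 log units; within the scatter) are all within the scatter, so compound 2 is not separated from either neighbour. Compound 4 `COc1cc(N2C(=O)[C@@H](Oc3ccccc3)[C@H]2c2ccc(N)cc2)cc(OC)c1OC` is not yet measured; it differs from compound 2 by amino in place of cyano on an aromatic carbon. The steps bearing on it are the aryl exchanges on the saturated ring carbon, none of which moved the number beyond the scatter, so no step beyond the scatter is expected here either, and the estimate is a 1.1-fold lower number from compound 2 to compound 4 (0.02 log units; within the scatter). Compound 4 is expected to give 30000 nM, in the range 12000 nM to 80000 nM.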

Compound 4, half-maximal inhibitory concentration: 160000 nM
Beside the measured number, compound 4's estimate is 5.3-fold (0.73 log units) below it; measured number above the stated range.
By their numbers in this assay, from the lowest: compounds 1, 3 and 2 (each within the scatter of the next); then compound 4.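

In this assay, among these compounds, the aryl group on the saturated ring carbon proves able to move the number: 4-aminophenyl gives the only steps beyond the scatter (a 5.1-fold higher number from compound 2 to compound 4 (0.70 log units; beyond the scatter)), (a 5.3-fold higher number from compound 3 to compound 4 (0.73 log units; beyond the scatter)) and (a 6.2-fold higher number from compound 1 to compound 4 (0.79 log units; beyond the scatter)). Compound 4 is therefore the weakest of the four, while the 4-cyanophenyl, 3-nitrophenyl and 3,4-dimethoxyphenyl compounds remain within the scatter of one another. No measurement in hand accounts for the loss on going from cyano to amino.

Open, going by these compounds, is whether an acetamide, a dimethylamino group or a hydroxyl in the same place would give a number like that of compound 4 or that of compound 2. Also open, on these data alone, is whether amino elsewhere on this ring would produce a similar step.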